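Halogen swap on the anilide of a triazole thioether series

The source may hold more compounds than are shown below. What is called first, only, known or untested is meant among the compounds shown, and "the series" means these compounds.

Of the compounds shown here, three sharing one core have been measured in an assay on isolated protein (Mus musculus) for inhibition of IL15-IL15 receptor (Homo sapiens), read by resazurin assay, with stated times of 30 min and 2.5 days; a lower number here means a stronger inhibitor, a higher number a weaker inhibitor. Compound 1 `Cn1c(Cc2nn(C)c(=O)c3ccccc23)nnc1SCCCCCCCC(=O)Nc1ccc(I)cc1` gives 1300 nM. Compound 2 `CCCOc1ccc(NC(=O)CCCCCCCSc2nnc(Cc3nn(C)c(=O)c4ccccc34)n2C)cc1` gives 1600 nM. Compound 3 `Cn1c(Cc2nn(C)c(=O)c3ccccc23)nnc1SCCCCCCCC(=O)Nc1ccc(Cl)cc1Cl` gives 1900 nM, which is the highest of the three numbers, yet its separation from the others is small: a 1.2-fold higher number from compound 2 to compound 3 (0.07 log units; within the scatter) and a 1.5-fold higher number from compound 1 to compound 3 (0.16 log units; within the scatter). The three therefore sit together within the scatter, and none can be called weaker or stronger than another.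

Compound 4 `Cn1c(Cc2nn(C)c(=O)c3ccccc23)nnc1SCCCCCCCC(=O)Nc1ccc(Br)cc1Br` differs from compound 3 only at the anilide end: 2,4-dibromophenyl in place of 2,4-dichlorophenyl on an amide-type nitrogen. The two steps that bear on this position, a 1.5-fold higher number from compound 1 to compound 3 (0.16 log units; within the scatter) and a 1.2-fold higher number from compound 2 to compound 3 (0.07 log units; within the scatter), show that changing the group on the amide-type nitrogen among iodo, propoxy and dichloro substitution moved the number by no more than the scatter. An exchange of one halogen pair for another at the same place is expected to behave likewise, so no step beyond the scatter is anticipated in this assay: no change at the digits printed from compound 3 to compound 4 (within the scatter). Compound 4 is accordingly estimated at 1900 nM, with a range from 800 nM to 4500 nM.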

Compound 4, half-maximal inhibitory concentration: 1500 nM
Compound 4: the middle estimate sits 1.3-fold (0.10 log units) above what was measured; measured number inside the range.
By their numbers in this assay, from the lowest: compounds 1, 4, 2 and 3 (each within the scatter of the next).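

In this assay the exchange of 2,4-dichlorophenyl for 2,4-dibromophenyl on the amide-type nitrogen gives a small step (a 1.3-fold lower number from compound 3 to compound 4 (0.10 log units; within the scatter)), so this halogen pair does not separate the two compounds. The steps to the other two groups at this place are equally small (a 1.1-fold lower number from compound 2 to compound 4 (0.03 log units; within the scatter); a 1.2-fold higher number from compound 1 to compound 4 (0.06 log units; within the scatter)), which places 2,4-dibromophenyl with 4-propoxyphenyl, 4-iodophenyl and 2,4-dichlorophenyl in a set that this assay does not tell apart. Nothing available here explains why these changes leave the number within the scatter.

Going by these compounds, whether an amine, a carboxylic acid or an unsubstituted phenyl at this place would give a step beyond the scatter remains open. So does the outcome of a shorter or longer chain in place of the present one, or of any change to the shared core.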